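Propyl to butyl on compound 1

The source may report more compounds than this note shows. Statements on the series, on what has been measured and on what is new or still open speak of the compounds shown alone.

In a functional assay on PC-3 cells (Homo sapiens) for inhibition, read by sulforhodamine B assay, with a stated time of 48 h, tested at 50 uM (a lower number here means less inhibition of growth, a higher number more inhibition of growth at the concentration tested), compound 1 (`CCCOc1ccc([C@@H]2CC(=O)c3cc(CC=C(C)C)c(OC)cc3O2)cc1`) gives 54%. Compound 2 (`COc1ccc([C@@H]2C/C(=N/OCc3cn(-c4ccc(O)cc4)nn3)c3cc(CC=C(C)C)c(OC)cc3O2)cc1`) gives 64% and compound 3 (`COc1ccc([C@@H]2C/C(=N/OCc3cn(-c4ccc(C#N)cc4)nn3)c3cc(CC=C(C)C)c(OC)cc3O2)cc1`) gives 50%, so compound 1 lies within the scatter of both.

Compound 4 (`CCCCOc1ccc([C@@H]2CC(=O)c3cc(CC=C(C)C)c(OC)cc3O2)cc1`) differs from compound 1 by a single change: methyl in place of hydrogen on a saturated chain carbon, three bonds along the chain from an oxygen on an aromatic ring. This is methyl in place of hydrogen on a saturated chain carbon, three bonds along the chain from an oxygen on an aromatic ring, and it takes propyl to butyl.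

Among the compounds with values here, the only measured step, a number 14 percentage points lower from compound 2 to compound 3 (beyond the scatter), is cyano in place of hydroxy on an aromatic carbon. It is a different change at a different place, so it gives no direct guide to its size. Within the data shown here, no measured pair tests this chain. The expectation therefore rests on compound 1 at 54%, and no step beyond the scatter is expected in this assay.

The expected step is a number 2 percentage points higher from compound 1 to compound 4 (within the scatter), which is estimated to lie within the scatter. Compound 4 is expected to give about 56%, with an estimated range from 43% to 68%.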

Compound 4, percent growth inhibition at one concentration: 48%
The estimate for compound 4 lay 8 percentage points above the measured number; low and high end bracket the measured number.
By their numbers in this assay, from the lowest: compounds 4, 3, 1 and 2 (each within the scatter of the next, the first and the last beyond it).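

In this assay, within the data shown here, the change from propyl to butyl is a number 6 percentage points lower from compound 1 to compound 4 (within the scatter) and gives the first direct reading of this chain, which the earlier step on the aromatic carbon could not supply. A methyl in place of hydrogen on a saturated chain carbon, three bonds along the chain from an oxygen on an aromatic ring, therefore leaves growth inhibition at this one concentration unchanged within what the assay can resolve. Nothing in the information at hand bears on this result.

On these data alone, this single pair supports no trend with chain length, so it remains open whether a longer chain such as hexyl would stay within the scatter. It also leaves open whether an amine or a carboxylic acid at the end of the chain would move the number.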